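This account rests on a few compounds, and the source may have more. Where it says the series, first, only, none or still open, it means among the compounds named here.

The measured compounds:
Compound 1, `Cc1cc(C(=O)Nc2cccc(F)c2)nn1Cc1cc(Cl)ccc1OCc1ccccc1`; in an assay on CHO-K1 cells for displacement of a labelled ligand from prostaglandin E2 receptor EP1 subtype (Homo sapiens) (on this read-out lower numbers stand for stronger inhibition and higher numbers for weaker inhibition), compound 1 gives 200 nM.
Compound 2, `Cc1cc(C(=O)Nc2ccc(F)cc2)nn1Cc1cc(Cl)ccc1OCc1ccccc1`; compound 2 gives 79.4 nM.
Compound 3, `Cc1cc(NC(=O)C(C)C)nn1Cc1cc(Cl)ccc1OCc1ccccc1`; compound 3 gives 25.1 nM.

Compound 2 stands second highest of these three numbers. Its nearest neighbour is compound 1, shown by a 2.5-fold lower number from compound 1 to compound 2 (0.40 log units; beyond the scatter); its furthest is compound 3, shown by a 3.2-fold lower number from compound 2 to compound 3 (0.50 log units; beyond the scatter).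

Compound 4, `Cc1cc(NC(=O)CC2CCCCC2)nn1Cc1cc(Cl)ccc1OCc1ccccc1`, has not been measured. It differs from compound 2 in one place: ((cyclohexylmethyl)carbonyl)amino in place of (4-fluorophenyl)carbamoyl on an aromatic carbon. Among the measured compounds shown here, the step bearing most directly on this change is the one to compound 3, where the same (4-fluorophenyl)carbamoyl gave way to an (isopropylcarbonyl)amino: a 3.2-fold lower number from compound 2 to compound 3 (0.50 log units; beyond the scatter). The comparable exchange starting from compound 1 gave an 8.0-fold lower number from compound 1 to compound 3 (0.90 log units; beyond the scatter). For the measured compounds named here, compound 4 resembles compound 3 at this position, differing only in a ((cyclohexylmethyl)carbonyl)amino rather than an (isopropylcarbonyl)amino, and no measured pair shows how that larger group behaves. A lowering of roughly the size seen for compound 3 is therefore expected, with wide uncertainty. For compound 4 the estimated step is a 3.2-fold lower number from compound 2 to compound 4 (0.50 log units; beyond the scatter). The expected value of compound 4 in this assay is 25 nM, within a range from 8 nM to 80 nM.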

Compound 4, half-maximal inhibitory concentration: 6.31 nM
Compound 4: middle estimate off by 4.0-fold (0.60 log units), on the high side; the whole stated range lies above it.
By their numbers in this assay, from the lowest: compound 4; then compound 3; then compound 2; then compound 1.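

Among the compounds shown here, at this position, on an aromatic carbon of the five-membered ring, the group on the carbonyl carbon of the amide proves to matter: in this assay cyclohexylmethyl in place of isopropyl gave a 4.0-fold lower number from compound 3 to compound 4 (0.60 log units; beyond the scatter) and so went beyond what the earlier compounds showed. The full exchange of the fluorophenylcarbamoyl groups for ((cyclohexylmethyl)carbonyl)amino therefore produced larger steps than those to compound 3, with a 13-fold lower number from compound 2 to compound 4 (1.10 log units; beyond the scatter) and a 32-fold lower number from compound 1 to compound 4 (1.50 log units; beyond the scatter) as the result. No evidence is available here on what lies behind this lowering.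

The compounds shown leave open whether a benzyl group, a plain cyclohexyl or a longer chain ending in cyclohexyl on the carbonyl carbon would lower the number further. They also do not tell how a cyclohexylmethylcarbamoyl group, with the amide reversed, would compare.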